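From sulfonyl to phenyl on the amine nitrogen

The source may report more compounds than this note shows. Statements on the series, on what has been measured and on what is new or still open speak of the compounds shown alone.

Four compounds share one core and differ in the group on an amine nitrogen. In a functional assay on VCaP cells (Homo sapiens) for antiproliferative activity, read by CCK-8 assay, with a stated time of 6 days (a lower number here means a stronger inhibitor, a higher number a weaker inhibitor), compound 1 (`C[C@@H](Cn1ccc(-c2ccc(C#N)c(Cl)c2)n1)NC(=O)c1ccccc1`) is recorded as "not determined" (no result reported), so it offers no number to compare. Compound 2 (`C[C@@H](Cn1ccc(-c2ccc(C#N)c(Cl)c2)n1)NC(=O)C1CC(=O)C1`) gives 22500 nM. Compound 3 (`C[C@@H](Cn1ccc(-c2ccc(C#N)c(Cl)c2)n1)NS(=O)(=O)c1cn(C)cn1`) gives 13600 nM, and these two values lie within the scatter of each other.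

Compound 4 (`C[C@@H](Cn1ccc(-c2ccc(C#N)c(Cl)c2)n1)Nc1ccccc1`) has phenyl in place of (1-methyl-1H-imidazol-4-yl)sulfonyl on an amine nitrogen. Going by the values given here, only one measured step bears on this change: a 1.7-fold lower number from compound 2 to compound 3 (0.22 log units; within the scatter). That step stays within the scatter, but it exchanges one group carrying a sulfonyl or carbonyl for another, whereas phenyl carries neither, so it is only a loose guide. No step beyond the scatter is therefore expected in this assay, though the uncertainty is wide. The expected step is a 1.1-fold higher number from compound 3 to compound 4 (0.04 log units; within the scatter). The estimate for compound 4 is 15000 nM, with an expected range from 5000 nM to 40000 nM.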

Compound 4, half-maximal inhibitory concentration: > 30000 nM
Compound 4 ended at the assay's limit (the forecaster's own chance of this, stated with the estimate: 20%); middle value at least 2.0-fold (0.30 log units) away from the limit.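

The result for compound 4 is a limit of this assay, not a number: the limit of > 30000 nM in this assay, at which 1 of the 4 values shown sits. Even so, it gives a readable step, an at least 2.2-fold higher number from compound 3 to compound 4 (0.34 log units; beyond the scatter), the first at this position to pass the scatter, and it shows that a phenyl set directly on the amine nitrogen, with no sulfonyl or carbonyl there, goes with weaker activity than the (1-methyl-1H-imidazol-4-yl)sulfonyl of compound 3. The comparison with the other measured compound is less firm, an at least 1.3-fold higher number from compound 2 to compound 4 (0.12 log units; that floor lies within the scatter), so no order can be set for that pair.

Compound 1, which carries a phenyl through a carbonyl, offers no number, so the phenyl itself cannot be separated from the loss of the carbonyl or sulfonyl link. As far as these compounds go, how a simple acetyl group or a carboxylic acid-bearing chain on this nitrogen would read in this assay also stays open.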